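Compound 3 to compound 4: a sulfur-bearing ring rearranged

The compounds below may be only part of what the source reports. "The series", "measured", "known", "first", "only" and "open" are said of these compounds alone.

Measured so far in an ADME assay on J774.A1 cells (Mus musculus) for cytotoxicity, read by MTT assay; a lower number here means a stronger inhibitor, a higher number a weaker inhibitor:
- compound 1 `N#Cc1ccc(OCCCCCn2cc(/C=C3\NC(=O)NC3=O)c3ccccc32)cc1`: 33 ug/mL
- compound 2 `O=C1NC(=S)N/C1=C\c1cn(CCCCCOc2ccccc2)c2ccccc12`: > 100 ug/mL (a limit of the assay, not a number)
- compound 3 `CSC1=N/C(=C\c2cn(CCCCCOc3ccc(C#N)cc3)c3ccccc23)C(=O)N1`: > 100 ug/mL (a limit of the assay, not a number)

Compound 3 has no exact value, and its position is known only as the limit of > 100 ug/mL in this assay, at which 2 of the 3 values shown sit. Compound 4 `CN1C(=S)NC(=O)/C1=C\c1cn(CCCCCOc2ccc(C#N)cc2)c2ccccc12` keeps the rest of compound 3 and changes one group: a group of 9 heavy atoms (5 carbon, 2 nitrogen, 1 oxygen, 1 sulfur; one five-membered non-aromatic ring with 2 hetero atoms) in place of a group of 9 heavy atoms (5 carbon, 2 nitrogen, 1 oxygen, 1 sulfur; one five-membered non-aromatic ring with 2 hetero atoms), on an aromatic carbon. The two have the same atoms, joined differently, and the change sits on an aromatic carbon of the shared core.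

Going by the values given here, one measured step bears directly on this place: an at least 3.0-fold higher number from compound 1 to compound 3 (0.48 log units; beyond the scatter). As far as these compounds go, that step ends at a limit, so its full size is unknown. Among the compounds with values here, both sulfur-bearing compounds measured so far sit at the limit, and no measured compound goes against this, although the sample is small. Compound 4 also carries sulfur, so a return towards compound 1 seems less likely than staying near the limit. In this assay, the expected change is an at least 1.1-fold lower number from compound 3 to compound 4 (0.04 log units; that floor lies within the scatter), with no step beyond the scatter expected in either direction.

For compound 4, the estimated value is 90 ug/mL, with an expected range of 40 ug/mL to 150 ug/mL.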

Compound 4, half-maximal inhibitory concentration: 14.8 ug/mL
Estimate against measurement, compound 4: 6.1-fold (0.78 log units) above, outside the stated range (below it).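

In this assay, this position responds to how the same atoms are joined, not only to which atoms are present: rearranging the sulfur-bearing ring gives an at least 6.7-fold lower number from compound 3 to compound 4 (0.82 log units; beyond the scatter). A sulfur-bearing ring therefore does not by itself hold a compound at the limit, and compound 4 goes against the pattern that compound 2 and compound 3 had suggested. The comparison with the oxygen-only ring gives a 2.2-fold lower number from compound 1 to compound 4 (0.35 log units; beyond the scatter), so with the earlier at least 3.0-fold higher number from compound 1 to compound 3 (0.48 log units; beyond the scatter), replacing that ring on the aromatic carbon can move the number in either direction, depending on the arrangement of the incoming ring.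

As far as these compounds go, compound 3 remains a limit and not a number, so the full size of the rearrangement step stays unknown: the limit of > 100 ug/mL in this assay, at which 2 of the 4 values shown sit. The compounds shown leave open whether the shift follows the methyl on the ring nitrogen or the placement of the sulfur, and whether an ethyl or a benzyl group on that ring nitrogen, or a carbonyl in place of the sulfur-bearing carbon of compound 4, would keep the number low in this assay.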